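Sulfur-Linked Pyridine Arm on a Nucleoside Core

The compounds below may be only part of what the source reports. "The series", "measured", "known", "first", "only" and "open" are said of these compounds alone.

Compound 2, with structure `COCc1ncnc2c1ncn2[C@@H]1O[C@H](CO)[C@@H](O)[C@H]1O`, carries a methoxymethyl arm on its core. In a functional assay on Huh-7 cells (Homo sapiens) for cytotoxicity, read by MTT assay, with a stated time of 3 days (a lower number here means that less compound is tolerated, a higher number that more compound is tolerated), compound 2 reaches only a limit of the assay, > 100000 nM, so no number is known for it. Its nearest measured neighbour, compound 1, with structure `OC[C@H]1O[C@@H](n2cnc3c(COc4ccccn4)ncnc32)[C@H](O)[C@@H]1O`, carries a pyridin-2-yl instead of methyl on that oxygen. In this assay compound 1 likewise stops at a limit, > 250000 nM. Among the compounds with values here, the single measured step, a step that the two limits leave unreadable from compound 1 to compound 2, cannot be read because the limit of > 100000 nM in this assay, at which 1 of the 2 values shown sits, and the limit of > 250000 nM in this assay, at which 1 of the 2 values shown sits, both sit at limits rather than at numbers.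

Compound 3, with structure `OC[C@H]1O[C@@H](n2cnc3c(CSc4ccccn4)ncnc32)[C@H](O)[C@@H]1O`, is the compound still to be measured. It differs from compound 2 as follows: (pyridin-2-yl)sulfanyl in place of methoxy on a saturated chain carbon bound to an aromatic carbon Both measured compounds were tolerated up to their limits, so no readable step points in either direction. Compound 3 is expected to behave the same way, and the expected step that the limit leaves unreadable from compound 2 to compound 3 is none beyond the scatter. For compound 3 the estimate in this assay is 200000 nM, within a range from 50000 nM to 1000000 nM, most likely again reported only as a limit.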

Compound 3, half-maximal cytotoxic concentration: > 100000 nM
Compound 3: only a limit was reported; the forecaster's own chance of this, stated with the estimate: 80%; the middle value lies beyond the limit too.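

In this assay compound 3 gives > 100000 nM, which is a limit and not a number. Its steps from compound 1 and compound 2 therefore cannot be read. The compounds shown leave open where the half-maximal cytotoxic concentration of each lies, and whether (pyridin-2-yl)sulfanyl differs at all from methoxy or (pyridin-2-yl)oxy.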